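Swapping the Aryl Group on a Well-Tolerated Compound

The compounds below may be only part of what the source reports. "The series", "measured", "known", "first", "only" and "open" are said of these compounds alone.

Compound 1 `OC[C@@H]1[C@@H](O)[C@H](O)[C@@H](O)CN1CCCCCCOc1cc(F)ccc1F` has been tested in an ADME assay on BHK cells (Mesocricetus auratus) for cytotoxicity, read by MTT assay; a lower number here means that less compound is tolerated, a higher number that more compound is tolerated. There compound 1 gives > 500000 nM, which is a limit of the assay and not a number, so its position is known only as a limit. Compound 2 `OC[C@@H]1[C@@H](O)[C@H](O)[C@@H](O)CN1CCCCCCOc1cccc(C(F)(F)F)c1` gives 400000 nM in this assay, and this one is a true number. These two readings are all that is available so far.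

Compound 3 `COc1ccc(OCCCCCCN2C[C@H](O)[C@@H](O)[C@H](O)[C@H]2CO)cc1` has not yet been measured. It differs from compound 1 by one change, 4-methoxyphenyl in place of 2,5-difluorophenyl on an oxygen on a saturated carbon. Going by the values given here, no measured pair of compounds isolates such a swap, so any expectation here is rough. Compound 2 also carries a different group in that place and still gives 400000 nM, a high reading on this scale. The expected outcome is an at least 1.1-fold lower number from compound 1 to compound 3 (0.04 log units; that floor lies within the scatter), which would mean no change beyond the usual scatter and no favoured direction. For compound 3 the estimated value is 450000 nM, with an expected range from 200000 nM to 800000 nM.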

Compound 3, half-maximal cytotoxic concentration: > 500000 nM
Compound 3 gave a limit, no number; the forecaster's own chance of this, stated with the estimate: 60%; middle value at least 1.1-fold (0.04 log units) away from the limit.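

In this assay compound 3 gives > 500000 nM, which is a limit of the assay and not a number. Going by these compounds alone, no step between compound 1 and compound 3 can be read, because both compounds stop at the same ceiling: the limit of > 500000 nM in this assay, at which 2 of the 3 values shown sit. The compounds shown leave open whether 4-methoxyphenyl and 2,5-difluorophenyl differ at all in how well they are tolerated.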